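This account rests on a few compounds, and the source may have more. Where it says the series, first, only, none or still open, it means among the compounds named here.

Of the compounds shown here, three built on a shared core have been measured in an assay on microsomes from liver for inhibition of 3-hydroxy-3-methylglutaryl-coenzyme A reductase (Rattus norvegicus); on this read-out lower numbers stand for stronger inhibition and higher numbers for weaker inhibition. Compound 1 `CC(C)c1c(C(=O)NCc2cccc(F)c2F)nn(-c2ccc(F)cc2)c1OC[C@@H](O)C[C@@H](O)CC(=O)O` gives 2 nM, compound 3 `COc1ccccc1CNC(=O)c1nn(-c2ccc(F)cc2)c(OC[C@@H](O)C[C@@H](O)CC(=O)O)c1C(C)C` gives 22 nM, and compound 2 `Cc1ccc(CN(C)C(=O)c2nn(-c3ccc(F)cc3)c(OC[C@@H](O)C[C@@H](O)CC(=O)O)c2C(C)C)cc1` gives 37 nM, the highest number of the three. Compound 4 `CC(C)c1c(C(=O)NCc2ccc(Cl)cc2)nn(-c2ccc(F)cc2)c1OC[C@@H](O)C[C@@H](O)CC(=O)O` has not yet been measured; its change from compound 2 is (4-chlorobenzyl)amino in place of methyl(4-methylbenzyl)amino on a carbonyl carbon. Among the measured compounds shown here, two measured steps touch the same place: a 19-fold higher number from compound 1 to compound 2 (1.27 log units; beyond the scatter), and a 1.7-fold lower number from compound 2 to compound 3 (0.23 log units; within the scatter). The first shows that altering this amide group can move the number strongly, while the second, from methyl(4-methylbenzyl)amino to (2-methoxybenzyl)amino, stayed within the scatter. A moderate step down from compound 2 is therefore expected, with wide uncertainty. Compound 4 is estimated at 10 nM, between 3 nM and 40 nM, which would mean an expected 3.7-fold lower number from compound 2 to compound 4 (0.57 log units; beyond the scatter).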

Compound 4, half-maximal inhibitory concentration: 6.7 nM
Compound 4: middle estimate off by 1.5-fold (0.17 log units), on the high side; measured number inside the range.
By their numbers in this assay, from the lowest: compound 1; then compound 4; then compounds 3 and 2 (each within the scatter of the next).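

In this assay, the change to (4-chlorobenzyl)amino gave a 5.5-fold lower number from compound 2 to compound 4 (0.74 log units; beyond the scatter), a step beyond the scatter where the change to (2-methoxybenzyl)amino had stayed within it. The amide hydrogen is kept in compounds 1, 3 and 4, yet a 3.3-fold lower number from compound 3 to compound 4 (0.52 log units; beyond the scatter) and a 3.4-fold higher number from compound 1 to compound 4 (0.53 log units; beyond the scatter), so the number at this carbonyl carbon also follows the ring substituents. Nothing shown explains these differences. Methyl(4-chlorobenzyl)amino would be needed to separate the methyl group from the chlorine, and whether an unsubstituted benzylamino group keeps this strength remains open.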